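This account rests on a few compounds, and the source may have more. Where it says the series, first, only, none or still open, it means among the compounds named here.

Compound 1 `CCc1ccc(NC(=O)Nc2cc(C)nc3ccccc23)cc1`: 16000 nM
Compound 2 `Cc1cc(NC(=O)Nc2ccccc2N)c2ccccc2n1`: > 25000 nM (a limit)
Compound 3 `Cc1cc(NC(=O)Nc2cccc([N+](=O)[O-])c2)c2ccccc2n1`: > 25000 nM (a limit)

All three compounds were tested in an ADME assay on HEK293 cells (Homo sapiens) for cytotoxicity, with a stated time of 72 h; a lower number here means that less compound is needed, a higher number that more compound is needed for the effect. Compound 1 gives a true number, 16000 nM. Compound 3 has no number, and its > 25000 nM is a limit of the assay. It stands at the limit of > 25000 nM in this assay, at which 2 of the 3 values shown sit, together with compound 2.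

Compound 4 `Cc1cc(NC(=O)Nc2cccc(C(N)=O)c2)c2ccccc2n1` has carbamoyl in place of nitro on an aromatic carbon, meta to a large group: carbamoyl in place of nitro on an aromatic carbon. Among the compounds with values here, no measured pair of compounds shows a change of this kind, so the data give no direct size for it. The expectation therefore rests on the position of compound 3 at the limit of > 25000 nM in this assay, at which 2 of the 3 values shown sit, and no step beyond the scatter is expected in this assay. The expected change is a step that the limit leaves unreadable from compound 3 to compound 4. Compound 4 is estimated at 28000 nM, with an expected range from 14000 nM to 50000 nM. It may well be reported only as a limit.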

Compound 4, half-maximal effective concentration: > 25000 nM
Compound 4 was reported as a limit (the forecaster's own chance of this, stated with the estimate: 75%); the middle value does not contradict the limit.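

Compound 3 and compound 4 are both reported only as limits in this assay, so no step can be read between them. The compounds shown leave open how large a change, if any, carbamoyl in place of nitro brings in this assay.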